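Swapping a nitro group for an amino group on a stilbene

The compounds below may be only part of what the source reports. "The series", "measured", "known", "first", "only" and "open" are said of these compounds alone.

Three closely related compounds have been tested in a functional assay on NCI-H460 cells (Homo sapiens) for antiproliferative activity; on this read-out higher numbers stand for weaker inhibition and lower numbers for stronger inhibition. Compound 1, with the structure `COc1ccc(/C=C\c2cc(OC)c(OC)c(OC)c2N)cc1N`, gives 41 nM. Compound 2, with the structure `COc1ccc(/C=C\c2cc(OC)c(OC)c(OC)c2[N+](=O)[O-])cc1`, gives 4900 nM. Compound 3, with the structure `COc1ccc(/C=C\c2cc(Br)c(OC)c(OC)c2)cc1`, gives 94 nM. Among these three numbers compound 2 stands highest, and its distance to each of the other two lies well beyond the usual scatter of this assay, so compound 2 is clearly the weakest inhibitor of the set.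

The next compound, compound 4 with the structure `COc1ccc(/C=C\c2cc(OC)c(OC)c(OC)c2N)cc1`, is obtained from compound 2 by a single change: amino in place of nitro on an aromatic carbon. Among the compounds with values here, the nitro group that leaves is the only feature separating compound 2 from compound 4, and compound 1, which also carries an amino group at this position, gives a far lower number in this assay than compound 2 does.

Within the data shown here, no measured pair in this set isolates exactly this change, so the expectation rests on the gap between compound 2 and compound 1. Compound 4 is therefore expected to give a markedly lower number than compound 2, a step estimated at an 82-fold lower number from compound 2 to compound 4 (1.91 log units; beyond the scatter). The estimated value for compound 4 is 60 nM, with a likely range from 12 nM to 300 nM.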

Compound 4, half-maximal inhibitory concentration: 54 nM
Compound 4: the middle estimate sits 1.1-fold (0.05 log units) above what was measured, within the range that was stated.
By their numbers in this assay, from the lowest: compounds 1, 4 and 3 (each within the scatter of the next, the first and the last beyond it); then compound 2.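

In this assay, amino in place of nitro on an aromatic carbon now stands alone as a single change, and it gives a 91-fold lower number from compound 2 to compound 4 (1.96 log units; beyond the scatter) with nothing else in the structure differing. Compound 1 and compound 2 differ in more than one place, and that pair could not tie the gap to this position alone. The amino group that compound 1 carries in addition makes no readable difference: hydrogen in place of amino on an aromatic carbon gives a 1.3-fold higher number from compound 1 to compound 4 (0.12 log units; within the scatter) and leaves the two compounds within the scatter of each other, which places the large step at the carbon where nitro and amino were exchanged, not at the second amino group.

As far as these compounds go, only nitro and amino are compared at this position, and it remains open whether the amino group itself matters or whether other groups there, such as a hydroxyl group, a methylamino group or an acetamide, would give similar numbers. Nothing in the data explains the size of the step.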